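One change on compound 1 and its expected half-life

The compounds below may be only part of what the source reports. "The series", "measured", "known", "first", "only" and "open" are said of these compounds alone.

Compound 1 `CC(C)C(Nc1nccs1)c1ccc(-c2ccc3cccc(F)c3c2)[nH]c1=O` gives 0.07 h.
Compound 2 `CCn1ncc2c(F)cc(-c3ccc(C(CC)(CC)c4ncn(C)n4)c(=O)[nH]3)cc21` gives > 3 h, which is a limit of the assay and not a number.

Both were tested in an ADME assay on microsomes from liver (Rattus norvegicus) for metabolic stability; a lower number here means that the compound disappears faster, a higher number that the compound lasts longer. Compound 1 holds the only true number shown, 0.07 h. Compound 2 sits at the limit of > 3 h in this assay, at which 1 of the 2 values shown sits, so it marks an edge of what this assay can report rather than a measured value. Within the data shown here, no pair of measured compounds differs in a single place, so no measured step is available.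

Compound 3 `CC(C)C(c1ccc(-c2ccc3cccc(F)c3c2)[nH]c1=O)N1CCCCS1(=O)=O` has not yet been measured. It differs from compound 1 in one place: a group of 8 heavy atoms (4 carbon, 1 nitrogen, 2 oxygen, 1 sulfur; one six-membered non-aromatic ring with 2 hetero atoms) in place of a group of 6 heavy atoms (3 carbon, 2 nitrogen, 1 sulfur; one five-membered aromatic ring with 2 hetero atoms), on a saturated chain carbon bound to an aromatic carbon and a saturated chain carbon. Among the measured compounds shown here, since no measured pair shows what this change does, the step is expected from the change itself: compound 3 is expected to last somewhat longer than compound 1, by a 2.9-fold higher number from compound 1 to compound 3 (0.46 log units; beyond the scatter), a step that may not exceed the usual scatter. Compound 3 is estimated at 0.2 h, with a range from 0.05 h to 0.8 h.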

Compound 3, half-life: 0.07 h
Estimate against measurement, compound 3: 2.9-fold (0.46 log units) above; the measured number falls inside the stated range.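

Among these compounds, at the saturated chain carbon bound to an aromatic carbon and a saturated chain carbon, swapping the (1,3-thiazol-2-yl)amino group for the six-membered non-aromatic ring with 2 hetero atoms gives, in this assay, no change at the digits printed from compound 1 to compound 3 (within the scatter), the first measured step at this position. In this pair, then, losing the aromatic ring and the hydrogen-bond donor of the leaving group, and adding a larger group with two double bonds outside aromatic rings, leaves the half-life unmoved. Nothing in the data shown explains this outcome.

From the compounds shown here alone, whether a different group on this carbon, such as a simple amine, a carboxylic acid or a longer chain, would move the half-life remains open. Also open, going by these compounds, is whether this same swap would give the same step on another core.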